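The source may hold more compounds than are shown below. What is called first, only, known or untested is meant among the compounds shown, and "the series" means these compounds.

Series notes. Compound 2 `NNC(=O)CN1C(=O)c2ccccc2NC1c1ccccc1` gives 38 nM in an assay on mitochondria for inhibition of Amine oxidase [flavin-containing] A (Bos taurus), read by fluorescence, with a stated time of 60 min (on this read-out higher numbers stand for weaker inhibition and lower numbers for stronger inhibition), and stands lowest of the three numbers taken so far. Compound 3 `COc1ccc(C2Nc3ccccc3C(=O)N2CC(=O)NN)cc1` gives 82 nM, the step of a 2.2-fold higher number from compound 2 to compound 3 (0.33 log units; beyond the scatter) being modest. Compound 1 `COC(=O)CN1C(=O)c2ccccc2NC1c1ccccc1` gives 930 nM, and the step of a 24-fold lower number from compound 1 to compound 2 (1.39 log units; beyond the scatter) is large. Compound 4 `NNC(=O)CCN1C(=O)c2ccccc2NC1c1ccccc1` is next. The change is (aminocarbamoyl)methyl in place of aminocarbamoyl on a saturated chain carbon bound to an amide-type nitrogen in a ring; cut one bond further out it reads as (aminocarbamoyl)methyl to 2-(aminocarbamoyl)ethyl. Neither measured step bears on this change directly: one swaps the group on the carbonyl carbon, the other adds to the aromatic ring. Going by the values given here, with no comparable step in hand, only a small to modest move in this assay is expected, if anything toward a higher number. The step expected is a 2.1-fold higher number from compound 2 to compound 4 (0.32 log units; beyond the scatter). For compound 4 the estimate is 80 nM, range 20 nM to 320 nM.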

Compound 4, half-maximal inhibitory concentration: 16 nM
For compound 4 the middle estimate is 5.0-fold (0.70 log units) above the measured one; the whole stated range lies above it.
By their numbers in this assay, from the lowest: compound 4; then compound 2; then compound 3; then compound 1.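

Chain length at this position now registers: going from (aminocarbamoyl)methyl to 2-(aminocarbamoyl)ethyl gives a 2.4-fold lower number from compound 2 to compound 4 (0.38 log units; beyond the scatter), so the added carbon lowers the number rather than raising it. Measured against methoxycarbonyl, the longer chain gives a 58-fold lower number from compound 1 to compound 4 (1.76 log units; beyond the scatter), which goes further than the change on the carbonyl carbon alone. Nothing available accounts for this shift.

From the compounds shown here alone, whether a longer chain would lower the number further remains open. So does how a carboxylic acid or an amine at the chain end would compare, and whether methoxy on the aromatic carbon shifts the number the same way with 2-(aminocarbamoyl)ethyl.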